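The compounds below may be only part of what the source reports. "The series", "measured", "known", "first", "only" and "open" are said of these compounds alone.

Measured in a functional assay on a cell-free system (Platelet, plasma, Homo sapiens) for inhibition; a lower number here means a stronger inhibitor, a higher number a weaker inhibitor:
- Compound 1 `COc1cccc(C(=O)N(CCN2CCC(OCC(=O)O)CC2)c2ccc(C)cc2)c1`: 32 nM
- Compound 2 `COc1cccc(C(=O)N(CCN2CCC(OCC(=O)O)CC2)c2ccc(C)cc2)c1OC`: 1600 nM

Compound 2 has the higher of the two numbers, so it is the weaker inhibitor. Compound 3 `COc1ccc(OC)c(C(=O)N(CCN2CCC(OCC(=O)O)CC2)c2ccc(C)cc2)c1` differs from it by 2,5-dimethoxyphenyl in place of 2,3-dimethoxyphenyl on a carbonyl carbon, with 2,5-dimethoxyphenyl in place of 2,3-dimethoxyphenyl on a carbonyl carbon. For the measured compounds named here, one measured step bears on this: a 50-fold higher number from compound 1 to compound 2 (1.70 log units; beyond the scatter), a large change for methoxy in place of hydrogen on an aromatic carbon. Going by the values given here, no measured compound carries the 2,5-dimethoxyphenyl group, so the direction is uncertain. A partial recovery is expected, and the estimated step is a 3.2-fold lower number from compound 2 to compound 3 (0.51 log units; beyond the scatter). For compound 3 the estimated value is 500 nM, with an expected range of 100 nM to 2500 nM.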

Compound 3, half-maximal inhibitory concentration: > 3000 nM
Compound 3: no number, only a limit (the forecaster's own chance of this, stated with the estimate: 3%); at least 6.0-fold (0.77 log units) between middle value and limit.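

In this assay compound 3 gives only a limit, > 3000 nM, not a number: the limit of > 3000 nM in this assay, at which 1 of the 3 values shown sits. Changing 2,3-dimethoxyphenyl to 2,5-dimethoxyphenyl brings no recovery, with an at least 1.8-fold higher number from compound 2 to compound 3 (0.27 log units; that floor lies within the scatter), so the order of these two compounds remains unsettled. The step of an at least 93-fold higher number from compound 1 to compound 3 (1.97 log units; beyond the scatter) shows that a large loss also comes with this second dimethoxy arrangement, so it is not confined to the 2,3-dimethoxyphenyl group. Still open, on these data alone, is whether any second group on this aromatic ring has the same effect, or only a second methoxy. A fluorine, a methyl or an amine in its place could separate the two.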